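The source may report more compounds than this note shows. Statements on the series, on what has been measured and on what is new or still open speak of the compounds shown alone.

Working notes on the series. In an ADME assay on L6 cells (Rattus norvegicus) for cytotoxicity (on this read-out lower numbers stand for stronger inhibition and higher numbers for weaker inhibition), compound 1 `Cc1nc(-c2ccccn2)nc(N)c1Cl` gives 85300 nM, compound 2 `Cc1nc(-c2ccccn2)nc(N(C)C)c1Cl` gives 115000 nM and compound 3 `Cc1nc(-c2ccccn2)nc(NCc2ccccc2)c1Cl` gives 70100 nM, which places compound 3 within the scatter of the other two. The next structure is compound 4 `Cc1nc(-c2ccccn2)nc(NCC2CCOC2)c1Cl`, with the change (oxolan-3-yl in place of phenyl on a saturated chain carbon bound to a nitrogen on an aromatic ring); in other words, benzyl becomes (oxolan-3-yl)methyl. Going by the values given here, two measured steps bear on this: a 1.3-fold higher number from compound 1 to compound 2 (0.13 log units; within the scatter), and a 1.2-fold lower number from compound 1 to compound 3 (0.09 log units; within the scatter), the latter introducing the benzyl itself. Neither goes beyond the scatter, so no step beyond the scatter is expected in this assay, in either direction. The estimated step is a 1.2-fold higher number from compound 3 to compound 4 (0.08 log units; within the scatter). Compound 4 is expected at 85000 nM, within a range of 42000 nM to 150000 nM.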

Compound 4, half-maximal inhibitory concentration: 125000 nM
The estimate for compound 4 lay 1.5-fold (0.17 log units) below the measured number, and the stated range covers the measured number.
By their numbers in this assay, from the lowest: compounds 3, 1, 2 and 4 (each within the scatter of the next).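

In this assay, oxolan-3-yl in place of phenyl gives a 1.8-fold higher number from compound 3 to compound 4 (0.25 log units; within the scatter), so at this place a non-aromatic ring with an oxygen and an aromatic carbon ring cannot be told apart. The group also stays within the scatter against the simpler nitrogen substituents, with a 1.5-fold higher number from compound 1 to compound 4 (0.17 log units; within the scatter) and a 1.1-fold higher number from compound 2 to compound 4 (0.04 log units; within the scatter). Nothing available explains these numbers. Open, as far as these compounds go, is whether a piperidine, a carboxylic acid or a longer chain on this nitrogen would give a step beyond the scatter. Also open, from the compounds shown here alone, is whether a group other than chlorine on the shared core would do so.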